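This account rests on a few compounds, and the source may have more. Where it says the series, first, only, none or still open, it means among the compounds named here.

Compound 1, `Cc1c(C(=O)/C=C/c2cccc([N+](=O)[O-])c2)[n+]([O-])c2ccccc2[n+]1[O-]`, gives 34000 nM.
Compound 2, `COc1ccc(/C=C/C(=O)c2c(C)[n+]([O-])c3ccccc3[n+]2[O-])cc1OC`, gives 25000 nM.
Compound 3, `Cc1c(C(=O)/C=C/c2ccc(Cl)cc2)[n+]([O-])c2ccccc2[n+]1[O-]`, gives 13000 nM.

These three numbers come from a functional assay on HSC-2 cells (Homo sapiens) for cytotoxicity, with a stated time of 48 h; a lower number here means that less compound is tolerated, a higher number that more compound is tolerated. Compound 3 has the lowest of the three numbers, but the gap to compound 2 lies within the usual scatter of repeated measurements, so the two cannot be told apart; only the gap to compound 1 lies beyond the scatter, and there compound 3 clearly gives the lower number. Within the data shown here, no pair among the three differs in a single place, so no single step has been measured so far.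

Compound 4, `Cc1ccc(/C=C/C(=O)c2c(C)[n+]([O-])c3ccccc3[n+]2[O-])cc1`, is the next to be measured. It differs from compound 3 in one place: methyl in place of chloro on an aromatic carbon. Among the measured compounds shown here, nothing among the measured compounds shows what such an exchange does here, so no step beyond the scatter is expected in either direction. The estimate therefore stays close to compound 3. Compound 4 is expected to give about 15000 nM in this assay, with a likely range from 6000 nM to 40000 nM. The estimated step of a 1.2-fold higher number from compound 3 to compound 4 (0.06 log units; within the scatter) is expected to remain within the scatter.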

Compound 4, half-maximal cytotoxic concentration: 8400 nM
Compound 4: middle estimate off by 1.8-fold (0.25 log units), on the high side; low and high end bracket the measured number.
By their numbers in this assay, from the lowest: compounds 4, 3, 2 and 1 (each within the scatter of the next, the first and the last beyond it).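

Among these compounds, this is the only single exchange measured so far, and in this assay it gives a 1.5-fold lower number from compound 3 to compound 4 (0.19 log units; within the scatter). At this position, on an aromatic carbon para to a large group, chloro and methyl therefore cannot be told apart, so compound 3 and compound 4 count as the same within the usual scatter of repeated measurements. Nothing shown here offers a reason for this outcome.

Chloro and methyl are both single-heavy-atom groups, so this one step says little about how much room for change the position has. On these data alone, whether a larger or very different group on the same carbon, such as an amine, a carboxylic acid or a longer chain, would shift the number beyond the scatter remains open.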